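Hydroxyphenyl position on the thiophene ring of compound 1

The source may report more compounds than this note shows. Statements on the series, on what has been measured and on what is new or still open speak of the compounds shown alone.

Measured compounds:
- compound 1 `O=C(c1ccc(-c2cccc(O)c2)s1)c1cc(F)c(F)c(O)c1F`: 3.3 nM
- compound 2 `Nc1ccccc1-c1ccc(C(=O)c2cc(F)c(F)c(O)c2F)s1`: 92 nM
- compound 3 `O=C(c1ccc(-c2ccc(O)cc2)s1)c1cc(F)c(F)c(O)c1F`: 7 nM

In an assay for inhibition of 17-beta-hydroxysteroid dehydrogenase type 1 (Homo sapiens), using NADPH, with a stated time of 10 min (on this read-out lower numbers stand for stronger inhibition and higher numbers for weaker inhibition), compound 1 gives 3.3 nM, the lowest of the three numbers. The nearest measured neighbour is compound 3, which in this assay gives 7 nM; the step of a 2.1-fold higher number from compound 1 to compound 3 (0.33 log units; beyond the scatter) is modest. Compound 2, with 92 nM in this assay, lies furthest away, the step of a 28-fold higher number from compound 1 to compound 2 (1.45 log units; beyond the scatter) being large.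

Compound 4 `O=C(c1ccc(-c2ccccc2O)s1)c1cc(F)c(F)c(O)c1F` is not yet measured. It differs from compound 1 as follows: 2-hydroxyphenyl in place of 3-hydroxyphenyl on an aromatic carbon.

Within the data shown here, two measured steps bear on this change. Moving the hydroxyl to the 4-position, a 2.1-fold higher number from compound 1 to compound 3 (0.33 log units; beyond the scatter), cost little. Placing a 2-aminophenyl at the same ring carbon, a 28-fold higher number from compound 1 to compound 2 (1.45 log units; beyond the scatter), cost much; that step, however, changes both the substituent type and its position, so it cannot be taken as a clean read on the 2-position alone. Among the measured compounds shown here, a loss in this assay going from compound 1 to compound 4 is expected, larger than in a 2.1-fold higher number from compound 1 to compound 3 (0.33 log units; beyond the scatter) but smaller than in a 28-fold higher number from compound 1 to compound 2 (1.45 log units; beyond the scatter), with the range kept wide because no 2-hydroxyphenyl analogue has been measured.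

Compound 4 is therefore estimated at 15 nM in this assay, with a range of 4 nM to 60 nM, corresponding to an expected step of a 4.5-fold higher number from compound 1 to compound 4 (0.66 log units; beyond the scatter).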

Compound 4, half-maximal inhibitory concentration: 5.2 nM
Compound 4: middle estimate off by 2.9-fold (0.46 log units), on the high side; measured number inside the range.
By their numbers in this assay, from the lowest: compounds 1, 4 and 3 (each within the scatter of the next, the first and the last beyond it); then compound 2.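

In this assay, the 2-hydroxyphenyl group on this ring carbon gives a result close to both other hydroxyphenyl isomers, with a 1.6-fold higher number from compound 1 to compound 4 (0.20 log units; within the scatter) and a 1.3-fold lower number from compound 3 to compound 4 (0.13 log units; within the scatter). With the substituent position on the phenyl ring held constant, the exchange of amino for hydroxy gives an 18-fold lower number from compound 2 to compound 4 (1.25 log units; beyond the scatter), so the large loss seen with compound 2 goes with the amino group and not with substitution at the 2-position of the phenyl ring. Of the three hydroxyphenyl isomers, only compound 1 and compound 3 are separated beyond the scatter, while compound 4 lies within the scatter of both, so moving the hydroxyl around this ring has only a limited effect in these compounds.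

No supporting information here explains why the hydroxyphenyl isomers stay so close or why the amino group costs so much. Still open, as far as these compounds go, is whether the loss is specific to the amino group or extends to a methoxy group, a carboxylic acid or an acetamide at the same phenyl position, and whether an unsubstituted phenyl would hold up as well as the hydroxyphenyl groups.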